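Allyl to butyl on the shared core: a single step

The compounds below may be only part of what the source reports. "The series", "measured", "known", "first", "only" and "open" are said of these compounds alone.

For the measured compounds named here, compound 1 `C=CCn1nc(Cc2ccc(Cl)cc2)c2ccccc2c1=O` is the only compound of the set with a number so far: in a functional assay on aorta with Alpha-1D adrenergic receptor (Rattus norvegicus) as the target (a higher number here means that more compound is needed for the effect, a lower number that less compound is needed), compound 1 gives 2600 nM. For compound 2 `C=CCn1nc(Cc2ccc(OC)cc2)c2ccccc2c1=O` the entry in this assay reads "not determined" (no result reported). Compound 3 `CCCCn1nc(Cc2ccc(Cl)cc2)c2ccccc2c1=O` differs from compound 1 in one place: propyl in place of vinyl on a saturated chain carbon bound to an aromatic nitrogen. Going by the values given here, no step between two measured compounds is available for this change, so the step is expected to stay within the usual scatter, with no clear direction; the expected step is a 1.0-fold lower number from compound 1 to compound 3 (0.02 log units; within the scatter). Compound 3 is estimated at 2500 nM in this assay, with a range from 1000 nM to 6000 nM.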

Compound 3, half-maximal effective concentration: > 100000 nM
Compound 3: only a limit was reported; the forecaster's own chance of this, stated with the estimate: 10%; middle value at least 40-fold (1.60 log units) from the limit.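

Allyl to butyl on the shared core is far from neutral, giving an at least 38-fold higher number from compound 1 to compound 3 (1.58 log units; beyond the scatter), so this position responds strongly to a small change in the chain. Compound 3 reads > 100000 nM in this assay, which is a limit of the assay and not a number. The size of the step therefore rests on a limit: the limit of > 100000 nM in this assay, at which 1 of the 3 values shown sits.

Chain length and the double bond change together here, and the compounds shown do not separate them. A plain propyl chain on the aromatic nitrogen, or a chain ending in an amine, would remain to be read.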